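Swapping a Methyl for Hydrogen at the Assay Limit

This account rests on a few compounds, and the source may have more. Where it says the series, first, only, none or still open, it means among the compounds named here.

In a functional assay on BaF3 cells (Mus musculus) for antiproliferative activity (a lower number here means that less compound is needed, a higher number that more compound is needed for the effect), compound 1 (`CCN1CCN(Cc2ccc(NC(=O)c3ccc(C)c(C#Cc4cnc(N)cn4)c3)cc2C(F)(F)F)CC1`) gives 860 nM as a measured number. In this assay compound 2 (`Cc1cn(-c2cc(NC(=O)c3ccc(C)c(C#Cc4cnc5[nH]ccc5c4)c3)cc(C(F)(F)F)c2)cn1`) reads > 10000 nM and that is a limit of the assay, not a number. So compound 2 has no exact position on the scale, which makes any step from it hard to size.

Compound 3 (`Cc1cn(-c2cc(NC(=O)c3cccc(C#Cc4cnc5[nH]ccc5c4)c3)cc(C(F)(F)F)c2)cn1`) differs from compound 2 in one place, with hydrogen in place of methyl on an aromatic carbon. For the measured compounds named here, no measured pair of compounds here shows what this swap does. A modest move toward a lower number is expected, and compound 3 may well stay at the limit too. The expected change is an at least 1.4-fold lower number from compound 2 to compound 3 (0.15 log units; that floor lies within the scatter) and no more than that. The estimate for compound 3 is 7000 nM (expected range 1200 nM to 10000 nM).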

Compound 3, half-maximal effective concentration: 2830 nM
Estimate against measurement, compound 3: 2.5-fold (0.39 log units) above; low and high end bracket the measured number.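

In this assay, hydrogen in place of methyl on an aromatic carbon, at the place ortho to a large group and para to a large group, gives an at least 3.5-fold lower number from compound 2 to compound 3 (0.54 log units; beyond the scatter). This shows that the methyl is not needed for a measurable effect in this pair, and that removing it moves the series off the assay limit and onto a readable number. The step can be stated only as a minimum, and its true size may be larger, because compound 2 has a limit and not an exact number: the limit of > 10000 nM in this assay, at which 1 of the 3 values shown sits.

The compounds shown leave open how other groups at this position, such as a chlorine atom, a methoxy group or an amine, would compare with hydrogen. They also leave open whether the same swap would have a similar effect on a different core, since compound 1 differs from compound 3 in more than one place.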